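A Larger Ring Group on a Poorly Stable Core

A few compounds are considered here, and "the series" means these few. Any claim that something is new, unique, unknown or untested is made for them only; others in the source may bear on it.

Compound 1 `CCOC(=O)C1c2c[nH]nc2CCN1S(=O)(=O)c1ccc(Cl)cc1` and compound 2 `CC(C)C1Cc2n[nH]cc2CN1S(=O)(=O)c1ccc(Cl)cc1` share the same core. In an ADME assay on microsomes from liver (Homo sapiens) for metabolic stability, using NADPH, with a stated time of 30 min, in the presence of a further agent that is not named here (on this read-out higher numbers stand for a more stable compound and lower numbers for a less stable compound), compound 1 gives 1%, and compound 2 gives 5%; the two numbers lie within the usual scatter of each other, so neither compound can be called the more stable one. Compound 3 `O=S(=O)(c1ccc(Cl)cc1)N1Cc2c[nH]nc2CC1c1ccc(Cl)cc1` differs from compound 2 by 4-chlorophenyl in place of isopropyl on a saturated ring carbon. Among the measured compounds shown here, no measured pair shows the effect of such a change. Given 5% for compound 2, the step of no change at the digits printed from compound 2 to compound 3 (within the scatter) is expected to stay within the scatter. Compound 3 is estimated at 5%, between 1% and 15%.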

Compound 3, percent of the compound remaining: 12%
For compound 3 the middle estimate is 7 percentage points below the measured one; low and high end bracket the measured number.
By their numbers in this assay, from the lowest: compounds 1, 2 and 3 (each within the scatter of the next, the first and the last beyond it).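

In this assay, the step is a number 7 percentage points higher from compound 2 to compound 3 (within the scatter), so this saturated ring carbon accepts a much larger group carrying an aromatic ring, yet the two compounds cannot be told apart. Swapping isopropyl for 4-chlorophenyl here therefore gives no readable gain in stability, and the numbers for both compounds stay low. Nothing measured here accounts for this result.

Still open, going by these compounds, is whether an amine, a carboxylic acid or a longer chain on this same carbon would move the number beyond the scatter. Whether a change elsewhere on the shared core would do so also remains unanswered.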